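The source may report more compounds than this note shows. Statements on the series, on what has been measured and on what is new or still open speak of the compounds shown alone.

Measured so far in an ADME assay on a cell-free system (plasma, Rattus norvegicus) for protein binding; a lower number here means a smaller unbound share, a higher number a larger unbound share of the compound:
- Compound 1 `Cc1cc(C)c2cc(C(=O)NC3CN(c4cc(Cl)ncc4Cl)C3)ccc2n1`: 0.002
- Compound 2 `Cc1cc(C)c2cc(C(=O)NC3CN(c4ccnc(F)c4F)C3)ccc2n1`: 0.013

Of these two, compound 2 holds the higher number, at 0.013, and the gap down to compound 1 lies beyond the scatter. Compound 3 `COc1cc(N2CC(NC(=O)c3ccc4nc(C)cc(C)c4c3)C2)c(Cl)cn1` has not yet been measured in this assay. It carries 5-chloro-2-methoxypyridin-4-yl in place of 2,3-difluoropyridin-4-yl on an amine nitrogen in a ring.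

For the measured compounds named here, only one measured step bears on this change. It is a 6.5-fold higher number from compound 1 to compound 2 (0.81 log units; beyond the scatter), with 2,3-difluoropyridin-4-yl replacing 2,5-dichloropyridin-4-yl at the same place, and it lies beyond the scatter. The entering group of compound 3 holds a chlorine, as does the group of compound 1, whereas the group leaving compound 2 holds none. Going by the values given here, compound 1, at 0.002, is thus taken as the nearer guide, though a single step is thin support and no measured compound carries a methoxy group. Much of the measured step is expected to be undone, toward a smaller unbound share. The expected step is a 4.3-fold lower number from compound 2 to compound 3 (0.64 log units; beyond the scatter). Compound 3 is estimated at 0.003, with an expected range of 0.0012 to 0.008.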

Compound 3, unbound fraction: 0.002
For compound 3 the middle estimate is 1.5-fold (0.18 log units) above the measured one; measured number inside the range.
By their numbers in this assay, from the lowest: compounds 1 and 3 (each within the scatter of the next); then compound 2.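

In this assay, 5-chloro-2-methoxypyridin-4-yl on the amine nitrogen of the four-membered ring gives a 6.5-fold lower number from compound 2 to compound 3 (0.81 log units; beyond the scatter) and so takes back the whole of the earlier rise, not just part of it. Methoxy in place of chloro on an aromatic carbon, a change the earlier compounds could not address, gives no change at the digits printed from compound 1 to compound 3 (within the scatter) and thus leaves the unbound fraction unmoved at this place while the other chlorine stays. Both chlorine-bearing groups now stand together with the low numbers and the 2,3-difluoropyridin-4-yl group of compound 2 alone with the higher one, although three compounds are too few to make this a rule.

On these data alone, it stays open whether a pyridine carrying an amine or a carboxylic acid in place of the remaining chlorine would return to the number of compound 2 or stay with compound 1 and compound 3. Nothing given here offers any explanation for why the unbound fraction shifts with these groups.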